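Notes on a fused triazole-thiadiazine series

The source may report more compounds than this note shows. Statements on the series, on what has been measured and on what is new or still open speak of the compounds shown alone.

Measured compounds in a functional assay on Huh-7 cells (Homo sapiens) for inhibition, read by sulforhodamine B assay, with a stated time of 72 h; on this read-out lower numbers stand for stronger inhibition and higher numbers for weaker inhibition:
compound 1, `CC(C)Cc1ccc(C(C)c2nnc3n2N=C(c2ccc(Cl)cc2)CS3)cc1`, 5700 nM
compound 2, `CC(c1ccc(-c2ccccc2)c(F)c1)c1nnc2n1N=C(c1ccc(Cl)cc1Cl)CS2`, 3700 nM
compound 3, `COc1ccc2cc(C(C)c3nnc4n3N=C(c3ccc(F)cc3)CS4)ccc2c1`, 7000 nM

Compound 2 gives the lowest number of the three in this assay, but its gap to compound 1 and its gap to compound 3 both lie within the scatter, so no ranking among the three can be drawn; the three numbers stand together. Within the data shown here, compound 1 and compound 3 differ from compound 2 at more than one place, so no single step between measured compounds is available.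

Compound 4, `CC(c1ccc(-c2ccccc2)c(F)c1)c1nnc2n1N=C(c1ccc(F)cc1)CS2`, has not yet been measured. It differs from compound 2 in one place: 4-fluorophenyl in place of 2,4-dichlorophenyl on a carbon with a double bond to nitrogen. Among the measured compounds shown here, the measured set contains no pair that isolates this change, so the direction of the step rests on the spread of the three numbers alone. Compound 3 carries the same 4-fluorophenyl on a different core and gives 7000 nM, which sits within the scatter of compound 2. The step from compound 2 to compound 4 is therefore expected to be small, most likely none beyond the scatter, with a slight lean toward a higher number, as a 1.4-fold higher number from compound 2 to compound 4 (0.13 log units; within the scatter). Compound 4 is estimated at 5000 nM in this assay, within a range of 2500 nM to 10000 nM.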

Compound 4, half-maximal inhibitory concentration: 4900 nM
Compound 4: the middle estimate sits 1.0-fold (0.01 log units) above what was measured; measured number inside the range.
By their numbers in this assay, from the lowest: compounds 2, 4, 1 and 3 (each within the scatter of the next).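

In this assay the series now has its first comparison that differs in one place, and it falls on the carbon with a double bond to nitrogen, where the step is a 1.3-fold higher number from compound 2 to compound 4 (0.12 log units; within the scatter) and does not separate the two compounds. Among these compounds, on this shared core, 2,4-dichlorophenyl and 4-fluorophenyl are therefore not told apart at this position, a reading that the earlier compounds, which differ at more than one place, could not give. No measurement on hand explains why the two groups read alike.

On these data alone, both groups compared here are halogen-bearing phenyl rings, so it remains open whether a different kind of group at this position, such as an aminophenyl, a carboxylic acid-bearing phenyl or an unsubstituted phenyl, would give a step beyond the scatter. The group on the other side of the core also remains unresolved, as no pair shown isolates a change there, and the place of compound 1 and compound 3 relative to the others cannot be assigned to any single group.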